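Swapping the Urea Aryl Group in a PLK1 Series

A few compounds are considered here, and "the series" means these few. Any claim that something is new, unique, unknown or untested is made for them only; others in the source may bear on it.

Measured compounds:
compound 1 `CCNc1cc(-c2ccc(NC(=O)Nc3ccc(OC)cc3)cc2OC)ccn1` with 31.1%
compound 2 `CCNc1cc(-c2ccc(NC(=O)Nc3ccc(C(F)(F)F)cc3)cc2OC)ccn1` with 40.7%

In an assay on isolated protein for inhibition of serine/threonine-protein kinase PLK1 (Homo sapiens), read by radiometric assay and 33P incorporation, with a stated time of 40 min, tested at 20 uM, in the presence of a further agent that is not named here (on this read-out lower numbers stand for less inhibition and higher numbers for more inhibition at the one concentration tested (going by the name of the read-out)), compound 2 gives 40.7%, and compound 1 gives 31.1%; the two sit within the usual scatter of each other, so neither stands apart. Among the compounds with values here, the only measured step, trifluoromethyl in place of methoxy on an aromatic carbon, was a number 9.6 percentage points higher from compound 1 to compound 2 (within the scatter). Compound 3 `CCNc1cc(-c2ccc(NC(=O)Nc3ccccc3Cl)cc2OC)ccn1` differs from compound 2 by 2-chlorophenyl in place of 4-(trifluoromethyl)phenyl on an amide-type nitrogen. Within the data shown here, no measured step covers the exchange of one aryl group for another, so the single small step gives no direction. Compound 3 is therefore expected to stay near compound 2, a step of a number 5.7 percentage points lower from compound 2 to compound 3 (within the scatter), with an estimate of 35% ranging from 12% to 58%.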

Compound 3, a percentage reported as inhibition, at one concentration (the size of the read-out at that concentration, not a potency): 53.6%
Compound 3: middle estimate off by 18.6 percentage points, on the low side; the measured number falls inside the stated range.
By their numbers in this assay, from the lowest: compounds 1 and 2 (each within the scatter of the next); then compound 3.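

On the amide-type nitrogen, the choice of aryl group does shift the result in this assay: 2-chlorophenyl in place of 4-(trifluoromethyl)phenyl gives a number 12.9 percentage points higher from compound 2 to compound 3 (beyond the scatter). Against 4-methoxyphenyl, the same group gives a number 22.5 percentage points higher from compound 1 to compound 3 (beyond the scatter). Both steps are modest, but unlike the earlier step they clear the scatter, so compound 3 stands above the other two. Nothing available explains why this group gives more inhibition. Also open, on these data alone, is how an aryl group bearing an amine or a carboxylic acid would behave on this nitrogen.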